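The compounds below may be only part of what the source reports. "The series", "measured", "known", "first", "only" and "open" are said of these compounds alone.

Of the compounds shown here, three have so far been measured in an assay on isolated protein for inhibition of Long-chain-fatty-acid--CoA ligase 1 (Mus musculus), read by mass spectrometry, with a stated time of 90 min, in the presence of a further agent that is not named here; a lower number here means a stronger inhibitor, a higher number a weaker inhibitor. Compound 3 `Cc1cccc(Cc2nc3cc(O[C@H]4CC[C@@H](C(N)=O)CC4)ccc3n2C)c1` gives 190 nM, the lowest of the three numbers. Compound 1 `Cc1cccc(Cc2c(C#N)c3cc(O[C@H]4CC[C@@H](C(=O)O)CC4)ccc3n2C)c1` gives 600 nM, a number beyond the scatter above that of compound 3, and compound 2 `Cn1c(Cc2cccc(C#N)c2)nc2cc(O[C@H]3CC[C@@H](C(=O)O)CC3)ccc21` gives 22000 nM, further still. No two of these differ in only one place, so no single step can be read from them. Compound 4 `Cc1cccc(Cc2nc3cc(O[C@H]4CC[C@@H](c5noc(=O)[nH]5)CC4)ccc3n2C)c1` has not yet been measured; it differs from compound 3 by a group of 6 heavy atoms (2 carbon, 2 nitrogen, 2 oxygen; one five-membered aromatic ring with 3 hetero atoms) in place of a group of 3 heavy atoms (1 carbon, 1 nitrogen, 1 oxygen; no ring), on a saturated ring carbon. Among the compounds with values here, with no comparable step to lean on, the change expected here is none beyond the scatter. Compound 4 is therefore estimated at 170 nM, within 45 nM to 650 nM, an expected step of a 1.1-fold lower number from compound 3 to compound 4 (0.05 log units; within the scatter).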

Compound 4, half-maximal inhibitory concentration: 100 nM
Estimate against measurement, compound 4: 1.7-fold (0.23 log units) above; the range from low to high includes it.
By their numbers in this assay, from the lowest: compounds 4 and 3 (each within the scatter of the next); then compound 1; then compound 2.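

Replacing carbamoyl with the five-membered aromatic ring with 3 hetero atoms on the saturated ring carbon gives a 1.9-fold lower number from compound 3 to compound 4 (0.28 log units; within the scatter) in this assay. This first single-place comparison shows that this position can hold a group of 6 heavy atoms instead of 3 without a change beyond the scatter. Nothing measured here bears on why the two groups read alike.

Going by these compounds, how an amine or a tetrazole ring would read on this carbon remains open. A carboxylic acid occurs only in compound 1 and compound 2, which differ from compound 3 in more than one place, so its effect here cannot be read.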